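The source may report more compounds than this note shows. Statements on the series, on what has been measured and on what is new or still open speak of the compounds shown alone.

Measured compounds in an ADME assay on microsomes from liver (Homo sapiens) for metabolic stability, read by LC-MS, using NADPH, tested at 5 uM; a higher number here means that the compound lasts longer, a lower number that the compound disappears faster:
compound 1 `NS(=O)(=O)c1cc(-c2nnc(CCl)o2)c(Cl)cc1SCc1ccccc1`, 0.235 h
compound 2 `NS(=O)(=O)c1cc(-c2nnc(CN3CCC(Cc4ccccc4)CC3)o2)c(Cl)cc1SCc1ccccc1`, 0.363 h
compound 3 `[N-]=[N+]=NCc1nnc(-c2cc(S(N)(=O)=O)c(SCc3ccccc3)cc2Cl)o1`, which reaches the limit of this assay at > 1 h

Compound 1 holds the lowest of the two numbers shown in this assay; compound 2 sits a short way from it, within the scatter. Compound 3 gives only a limit, not a number.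

Among the measured compounds shown here, one measured step bears on the chloromethyl group of compound 1: an at least 4.2-fold higher number from compound 1 to compound 3 (0.62 log units; beyond the scatter). That step runs against (the limit of > 1 h in this assay, at which 1 of the 3 values shown sits), so its full size is not known.

Compound 4 `NS(=O)(=O)c1cc(-c2nnc(/C=C/c3ccccc3)o2)c(Cl)cc1SCc1ccccc1` is not yet measured. It differs from compound 1 in the same position: 2-phenylethenyl in place of chloromethyl on an aromatic carbon. For the measured compounds named here, the single measured step shows that replacing the chloromethyl group moves the number up, but the group entering here is not the one entering in compound 3, so the step from compound 1 to compound 3 only sets the direction, not the size. A modest upward step is therefore expected, a 2.3-fold higher number from compound 1 to compound 4 (0.37 log units; beyond the scatter), with a real chance that the assay again reports only its limit.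

Compound 4 is estimated at 0.55 h, expected to lie between 0.22 h and 1.4 h.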

Compound 4, half-life: 0.228 h
The estimate for compound 4 lay 2.4-fold (0.38 log units) above the measured number; low and high end bracket the measured number.
By their numbers in this assay, from the lowest: compounds 4, 1 and 2 (each within the scatter of the next). At a limit, above all of these: compound 3.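

In this assay, replacing the chloromethyl group does not in itself change the number: a 1.0-fold lower number from compound 1 to compound 4 (0.01 log units; within the scatter). The gain seen earlier therefore does not extend to every group entering on this aromatic carbon, and among the groups shown here, 2-phenylethenyl stays level with chloromethyl while azidomethyl stands apart: an at least 4.3-fold lower number from compound 3 to compound 4 (0.64 log units; beyond the scatter). Compound 3 gives a limit and not a number, so the full size of that last step is not known: the limit of > 1 h in this assay, at which 1 of the 4 values shown sits.

Still open, from the compounds shown here alone, is whether a saturated 2-phenylethyl chain, a simple amine or a carboxylic acid on this carbon would stay level with compound 1 and compound 4 or come closer to compound 3. The compounds shown also do not tell which part of these structures is lost in this assay, or whether the shared core and its benzylthio group set the short half-lives of compound 1 and compound 4 whatever group sits at this position.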